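From 3-methoxyphenyl to 2-cyclopropylphenyl on the shared core

A few compounds are considered here, and "the series" means these few. Any claim that something is new, unique, unknown or untested is made for them only; others in the source may bear on it.

Among the compounds with values here, in an ADME assay (liver) for metabolic stability, with Liver microsome (Homo sapiens) as the target, read by LC-MS, using microsomes, with a stated time of 30 min, tested at 4 uM (a lower number here means that less of the compound is left, a higher number that more of the compound is left), compound 3 (`COc1cccc(-c2nc3c(N4CCN(C)CC4)nc(C)nc3n2C2CCOCC2)c1`) gives 40%, the highest of the three numbers so far. Compound 1 (`Cc1nc(N2CCN(C)CC2)c2nc(-c3ccccc3C(F)(F)F)n(C3CCOCC3)c2n1`) gives 24%, and compound 2 (`COc1ccccc1-c1nc2c(N3CCN(C)CC3)nc(C)nc2n1C1CCOCC1`) gives 22%.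

Compound 4 (`Cc1nc(N2CCN(C)CC2)c2nc(-c3ccccc3C3CC3)n(C3CCOCC3)c2n1`) carries 2-cyclopropylphenyl in place of 3-methoxyphenyl on an aromatic carbon. Within the data shown here, no measured compound contains a cyclopropyl group, so the expectation rests on the nearest comparisons. The name of the new group matches the 2-methoxyphenyl of compound 2 and the 2-(trifluoromethyl)phenyl of compound 1 more closely than the group of compound 3.

Two modest steps bear on this: a number 18 percentage points higher from compound 2 to compound 3 (beyond the scatter) and a number 16 percentage points higher from compound 1 to compound 3 (beyond the scatter). A third, a number 2 percentage points lower from compound 1 to compound 2 (within the scatter), shows no separation between those two groups.

Reading those modest steps in reverse, a modest fall is expected, with the estimated step being a number 17 percentage points lower from compound 3 to compound 4 (beyond the scatter). For compound 4 the estimated value is 23%, with an expected range of 10% to 38%.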

Compound 4, percent of the compound remaining: 33%
Compound 4: middle estimate off by 10 percentage points, on the low side, and the stated range covers the measured number.
By their numbers in this assay, from the lowest: compounds 2, 1, 4 and 3 (each within the scatter of the next, the first and the last beyond it).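

In this assay the step reads a number 7 percentage points lower from compound 3 to compound 4 (within the scatter), so on this aromatic carbon 2-cyclopropylphenyl cannot be told apart from 3-methoxyphenyl, which compound 1 and compound 2 had not shown for any group with its substituent named at the 2 position. The comparison within that set is split: cyclopropyl in place of methoxy gives a number 11 percentage points higher from compound 2 to compound 4 (beyond the scatter), whereas cyclopropyl in place of trifluoromethyl gives a number 9 percentage points higher from compound 1 to compound 4 (within the scatter), so only the first separates the groups. Nothing measured here explains these numbers.

As far as these compounds go, it remains open how a nitrile or an isopropyl group in place of cyclopropyl would read in this assay. From the compounds shown here alone, it also remains open whether 3-cyclopropylphenyl would differ from 2-cyclopropylphenyl as 3-methoxyphenyl differs from 2-methoxyphenyl.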